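The source may report more compounds than this note shows. Statements on the series, on what has been measured and on what is new or still open speak of the compounds shown alone.

Among the three compounds measured in a functional assay on A549 cells (Homo sapiens) for cytotoxicity, read by MTT assay, with a stated time of 72 h (a higher number here means that more compound is needed for the effect, a lower number that less compound is needed), compound 2 `CCCCCc1cc(Nc2ccc(OC)cc2)cc(=O)o1` gives the highest number, 4.42 uM. Compound 1 `COc1cccc(Nc2cc(-c3ccccc3)oc(=O)c2)c1` gives 0.63 uM, the nearest value to it, and compound 3 `Cc1ccc(Nc2cc(-c3ccccc3)oc(=O)c2)cc1` gives 0.067 uM, the furthest; both gaps from compound 2 lie beyond the scatter. Compound 4 `COc1ccc(Nc2cc(C3CCCC3)oc(=O)c2)cc1` has not yet been measured in this assay. It differs from compound 2 in one place: cyclopentyl in place of pentyl on an aromatic carbon. Among the compounds with values here, no measured pair shows this change on its own, so there is no step to lean on. The expected change is a 1.8-fold lower number from compound 2 to compound 4 (0.25 log units; within the scatter), a step that is not expected to reach clearly beyond the scatter. The estimate for compound 4 in this assay is therefore 2.5 uM, within a range from 0.6 uM to 10 uM.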

Compound 4, concentration for half-maximal effect: 5.42 uM
Beside the measured number, compound 4's estimate is 2.2-fold (0.34 log units) below it; low and high end bracket the measured number.
By their numbers in this assay, from the lowest: compound 3; then compound 1; then compounds 2 and 4 (each within the scatter of the next).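

In this assay, the step from pentyl to cyclopentyl on this aromatic carbon next to the ring oxygen is a 1.2-fold higher number from compound 2 to compound 4 (0.09 log units; within the scatter). Closing the same five carbons into a ring therefore leaves the two compounds indistinguishable in this assay, the first direct reading of this change at this position. No measurement shown offers an explanation for this result. Compounds 1 and 3 differ from compound 2 in more than one place, so they cannot show what phenyl does here. As far as these compounds go, whether a propyl chain, a cyclohexyl ring or a chain ending in an amine would behave alike remains open.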